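From bromo to methyl on the shared core

The compounds below may be only part of what the source reports. "The series", "measured", "known", "first", "only" and "open" are said of these compounds alone.

Compound 1 `COc1cc(Sc2c(C)[nH]c3ccc(Cl)cc23)cc(OC)c1OC` gives 82 nM
Compound 2 `COc1cc(Sc2c[nH]c3ccc(Br)cc23)cc(OC)c1OC` gives 43 nM

In a functional assay on MCF7 cells (Homo sapiens) for inhibition, with a stated time of 48 h (a lower number here means a stronger inhibitor, a higher number a weaker inhibitor), compound 2 gives 43 nM and compound 1 gives 82 nM so the two values lie within the usual scatter of each other. Compound 2 therefore stands level with compound 1 on these numbers.

Compound 3 `COc1cc(Sc2c[nH]c3ccc(C)cc23)cc(OC)c1OC` has not yet been measured. It carries methyl in place of bromo on an aromatic carbon and is otherwise the same as compound 2. Among the measured compounds shown here, no measured pair shows a change in one place, so the data offer no direct guide to this exchange. The expectation starts from compound 2 at 43 nM and leans only slightly towards a higher number. The step expected is a 1.4-fold higher number from compound 2 to compound 3 (0.14 log units; within the scatter) and thus none beyond the scatter. For compound 3 the expected value is 60 nM within an estimated range of 20 nM to 180 nM in this measurement.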

Compound 3, half-maximal inhibitory concentration: 16 nM
Beside the measured number, compound 3's estimate is 3.8-fold (0.57 log units) above it; measured number outside the range, below it.
By their numbers in this assay, from the lowest: compound 3; then compounds 2 and 1 (each within the scatter of the next).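

This is the only change in a single place among the compounds shown, and in this assay methyl in place of bromo on an aromatic carbon gives a 2.7-fold lower number from compound 2 to compound 3 (0.43 log units; beyond the scatter) as a modest step beyond the scatter. It shows that bromine is not needed for activity at this place on the six-membered aromatic ring of carbon only, since a methyl group there gives the lowest number of the three compounds. Nothing at hand accounts for the size or direction of this step.

The compounds shown leave open how an ethyl group or an amine at this same place would compare with methyl and bromo. They also leave open whether the exchange of bromo for methyl would give a similar step on the core of compound 1.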